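Notes on a methoxyaryl series in a cellular activation read-out

The compounds below may be only part of what the source reports. "The series", "measured", "known", "first", "only" and "open" are said of these compounds alone.

Compound 2 `COc1ccc(-n2cnc3cnc(-c4ccc(F)cc4C)cc32)cc1` gives 6 nM in a functional assay on HL-60 cells (Homo sapiens) for activation, read by flow cytometry, with a stated time of 4 days; on this read-out higher numbers stand for an effect only at larger amounts of compound and lower numbers for an effect already at smaller amounts. Among the two numbers seen, compound 2 stands lowest; its nearest neighbour is compound 1 `COc1ccc(-n2cnc3cnc(-c4ccc(F)cc4C)cc32)cc1OC`, which in this assay gives 15 nM, the change being a 2.5-fold lower number from compound 1 to compound 2 (0.40 log units; beyond the scatter). Compound 3 `COc1ccc(-n2cnc3cnc(-c4ccc(F)cc4C)cc32)cc1C(C)C` in this assay returns only a limit, > 10000 nM, and this is the value that sits at the limit of > 10000 nM in this assay, at which 1 of the 3 values shown sits. Against compound 2 that is an at least 1600-fold higher number from compound 2 to compound 3 (3.22 log units; beyond the scatter), and against compound 1 it is an at least 660-fold higher number from compound 1 to compound 3 (2.82 log units; beyond the scatter).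

Compound 4 `COc1ccc(-n2cnc3cnc(-c4ccc(F)cc4C)cc32)nc1` is not yet measured. It differs from compound 2 in one place: 5-methoxypyridin-2-yl in place of 4-methoxyphenyl on an aromatic nitrogen. Within the data shown here, the measured steps all alter a substituent on that six-membered ring while keeping the carbon-only ring itself; none exchanges the ring for a pyridine, so no measured step bears directly on this change. Among the measured compounds shown here, with no direct precedent, a step within the scatter in this assay is the working expectation. Compound 4 is therefore estimated at 9 nM, between 3 nM and 40 nM. The expected step is a 1.5-fold higher number from compound 2 to compound 4 (0.18 log units; within the scatter).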

Compound 4, half-maximal effective concentration: 30 nM
Estimate against measurement, compound 4: 3.3-fold (0.52 log units) below, and the stated range covers the measured number.
By their numbers in this assay, from the lowest: compound 2; then compounds 1 and 4 (each within the scatter of the next). At a limit, above all of these: compound 3.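

Placing 5-methoxypyridin-2-yl in place of 4-methoxyphenyl on the aromatic nitrogen gives, in this assay, a 5.0-fold higher number from compound 2 to compound 4 (0.70 log units; beyond the scatter). Among these compounds, this is the first reading of a change to the ring itself rather than to a substituent on it: with the heavy-atom count unchanged, exchanging one ring carbon for nitrogen moves the number beyond the scatter, while compound 4 still gives a measured value of 30 nM. Nothing available here bears on the reason for this step.

The compounds shown leave open whether the step depends on where the nitrogen sits in the ring, and whether it would persist with the methoxy group removed from the pyridine. Also open, as far as these compounds go, is how an amine, a carboxylic acid or a longer alkoxy chain in place of the methoxy group would read out on either ring.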